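Isopropyl in place of methyl on compound 2

The source may report more compounds than this note shows. Statements on the series, on what has been measured and on what is new or still open speak of the compounds shown alone.

In a functional assay on MT4 cells (Homo sapiens) for cytotoxicity (on this read-out higher numbers stand for lower toxicity in this test and lower numbers for higher toxicity in this test), compound 2 (`Cc1c(O)nc(SCC(=O)c2ccc(F)cc2)nc1Cc1cccc2ccccc12`) stands at >= 275000 nM and this is a limit of the assay, not a number. Compound 3 (`Cc1c(O)nc(SCC(=O)c2ccc(Cl)cc2)nc1Cc1cccc2ccccc12`) also gives only a limit (>= 198000 nM). Among the compounds with values here, compound 1 (`CC(=O)CSc1nc(O)c(C)c(Cc2cccc3ccccc23)n1`) gives the one true number (85000 nM).

Compound 4 (`CC(C)c1c(O)nc(SCC(=O)c2ccc(F)cc2)nc1Cc1cccc2ccccc12`) carries isopropyl in place of methyl on an aromatic carbon and otherwise matches compound 2.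

Within the data shown here, no measured step touches that carbon. The steps at hand lie elsewhere: an at least 3.2-fold higher number from compound 1 to compound 2 (0.50 log units; beyond the scatter) and an at least 2.3-fold higher number from compound 1 to compound 3 (0.36 log units; beyond the scatter) are both beyond the scatter and at least modest, with an aryl group in place of methyl on a carbonyl carbon, while a step that the two limits leave unreadable from compound 2 to compound 3 cannot be read. These steps are therefore only a weak guide to the change at hand. Starting from the limit of >= 275000 nM in this assay, at which 1 of the 3 values shown sits, only a move toward a lower number could be read, and a small one is expected. The expected step is an at least 1.7-fold lower number from compound 2 to compound 4 (0.23 log units; that floor lies within the scatter) and it is not expected to exceed the size of the steps from compound 1 in this assay by much. The estimated value for compound 4 is 160000 nM with an expected range from 60000 nM to 260000 nM in this read-out.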

Compound 4, half-maximal cytotoxic concentration: 186000 nM
For compound 4 the middle estimate is 1.2-fold (0.07 log units) below the measured one; the measured number falls inside the stated range.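

Isopropyl in place of methyl on this aromatic carbon, ortho to a hydroxy group and two atoms from the ring nitrogen, gives the first reading for this position in this assay, with an at least 1.4-fold lower number from compound 2 to compound 4 (0.16 log units; that floor lies within the scatter) as its step. Within the data shown here, that floor lies within the scatter, so the limit-bound pair shows no firm move in this read-out, although compound 4 is the first compound here with an aryl group on the carbonyl carbon to give a number rather than a limit. As far as these compounds go, the real size of the step stays open at its upper end because compound 2 gives only a limit and not a number: the limit of >= 275000 nM in this assay, at which 1 of the 4 values shown sits.

The step from compound 2 to compound 3 cannot be read, so the choice between fluoro and chloro on the aromatic carbon remains unresolved in this assay. From the compounds shown here alone, how this read-out responds at the carbon ortho to the hydroxy group to an ethyl group, a longer chain, an amine or a carboxylic acid remains open, as does the effect of isopropyl alongside the 4-chlorophenyl group of compound 3.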